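Swapping Fluoro for Trifluoromethyl on a Fused Two-Ring Core

A few compounds are considered here, and "the series" means these few. Any claim that something is new, unique, unknown or untested is made for them only; others in the source may bear on it.

Measured so far:
- compound 1, `O=C(Nc1cccc(Cl)c1)c1ccccc1O`, gives 174 nM in an assay for inhibition of acyl-CoA (8-3)-desaturase (Homo sapiens); a lower number here means a stronger inhibitor, a higher number a weaker inhibitor
- compound 2, `Fc1ccc2[nH]nc(Nc3cccc(Cl)c3)c2c1`, gives 58 nM in this assay

Of the two compounds measured, compound 2 has the lowest number, so it is the stronger inhibitor of the pair. Its nearest neighbour is compound 1, whose number is higher by an amount that lies beyond the usual scatter of repeated measurements. The two compounds share the same chloro-substituted aniline piece but rest on different cores, so their values can be compared but no single structural step explains the gap.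

Compound 3, `FC(F)(F)c1ccc2[nH]nc(Nc3cccc(Cl)c3)c2c1`, keeps the core of compound 2 and changes one group on it: trifluoromethyl in place of fluoro on an aromatic carbon. Among the compounds with values here, with no measured pair of this kind to draw on, the size of the effect is open. A modest shift in either direction, not clearly beyond the scatter, is the most that can be expected. The step from compound 2 to compound 3 is estimated at a 1.1-fold lower number from compound 2 to compound 3 (0.02 log units; within the scatter). Compound 3 is therefore expected to give about 55 nM, within a range from 15 nM to 200 nM.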

Compound 3, half-maximal inhibitory concentration: 254 nM
Compound 3: middle estimate off by 4.6-fold (0.66 log units), on the low side; the measured number lies above the stated range.
By their numbers in this assay, from the lowest: compound 2; then compounds 1 and 3 (each within the scatter of the next).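

In this assay, placing trifluoromethyl in place of fluoro on this aromatic carbon of the shared core gives a 4.4-fold higher number from compound 2 to compound 3 (0.64 log units; beyond the scatter), a step beyond the scatter towards weaker inhibition. Within the data shown here, this is the first direct evidence on this position, since compounds 1 and 2 rest on different cores and could not show what a single change here does: the position is not indifferent to which group it carries, and in this pair fluoro is the better of the two. The two structures show what changed but not why the number rose, and no supporting measurement bears on the cause.

From the compounds shown here alone, only fluoro and trifluoromethyl appear at this carbon, so it remains open where plain hydrogen, a methyl group, a nitrile, a methoxy group or an amine would fall in this assay, and whether any of them would match or improve on compound 2. Going by these compounds, it is also open whether the same swap would cost as much at another carbon of this ring, or with a different group in place of the chloro substituent on the aniline piece.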